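Cyclohexyl to isopropyl on the amide of a bile acid receptor series

A few compounds are considered here, and "the series" means these few. Any claim that something is new, unique, unknown or untested is made for them only; others in the source may bear on it.

Measured so far:
Compound 1, `CCOc1cccc(-c2ccc(CN(C(=O)C3CCCCC3)c3cccc(/C=C/C(=O)OC)c3)cc2)c1`: 147 nM
Compound 2, `CCOc1cccc(-c2ccc(CN(C(=O)C(C)C)c3cccc(/C=C/C(=O)OC)c3)cc2)c1`: 173 nM
Compound 3, `COC(=O)/C=C/c1cccc(N(Cc2ccc(-c3cccc(Cl)c3)cc2)C(=O)C2CCCCC2)c1`: 94 nM

All three were tested in an assay on isolated protein with Bile acid receptor (Homo sapiens) as the target; on this read-out higher numbers stand for an effect only at larger amounts of compound and lower numbers for an effect already at smaller amounts. Compound 1 and compound 2 share one core and differ in a single spot, (isopropyl in place of cyclohexyl on a carbonyl carbon), and this gave a 1.2-fold higher number from compound 1 to compound 2 (0.07 log units; within the scatter). Compound 3 differs from compound 1 at another spot, (chloro in place of ethoxy on an aromatic carbon), with a 1.6-fold lower number from compound 1 to compound 3 (0.19 log units; within the scatter).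

Compound 4, `COC(=O)/C=C/c1cccc(N(Cc2ccc(-c3cccc(Cl)c3)cc2)C(=O)C(C)C)c1`, has not yet been measured in this assay. It stands to compound 3 exactly as compound 2 stands to compound 1: isopropyl in place of cyclohexyl on a carbonyl carbon. The place of the change is described in the same words for both pairs, so this is the same change on a core that differs only as described above.

For compound 4 a step of a 1.2-fold higher number from compound 3 to compound 4 (0.07 log units; within the scatter) is expected, resting on the step from compound 1 to compound 2, a 1.2-fold higher number from compound 1 to compound 2 (0.07 log units; within the scatter), since the change and its place are the same. Compound 4 is therefore estimated at 110 nM in this assay. The estimate for compound 4 is expected to fall between 55 nM and 220 nM.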

Compound 4, half-maximal effective concentration: 77 nM
Compound 4: the middle estimate sits 1.4-fold (0.15 log units) above what was measured; measured number inside the range.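

In this assay the swap of cyclohexyl for isopropyl on the carbonyl carbon gave a 1.2-fold lower number from compound 3 to compound 4 (0.09 log units; within the scatter) and agrees with its earlier step, so it carries across these two cores as a change too small to separate from the scatter: the same change on two cores in this assay, a 1.2-fold higher number (0.07 log units; within the scatter) from compound 1 to compound 2 and a 1.2-fold lower number (0.09 log units; within the scatter) from compound 3 to compound 4, 1.4-fold (0.16 log units) apart, within the scatter of two such steps.
The swap of ethoxy for chloro gave a 2.2-fold lower number from compound 2 to compound 4 (0.35 log units; beyond the scatter) and also agrees with its earlier step: the same change on two cores in this assay, a 1.6-fold lower number (0.19 log units; within the scatter) from compound 1 to compound 3 and a 2.2-fold lower number (0.35 log units; beyond the scatter) from compound 2 to compound 4, 1.4-fold (0.16 log units) apart, within the scatter of two such steps.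
Among these compounds, each change has been seen on only two cores, so this does not show that either would carry over to a third core.

The compounds shown leave open how a carboxylic acid in place of the methyl ester would read in this assay. They also leave open the effect of a longer chain in place of isopropyl on the carbonyl carbon.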